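The compounds below may be only part of what the source reports. "The series", "measured", "known", "first", "only" and "open" are said of these compounds alone.

Measured compounds:
Compound 1 `COc1cc(-c2nn(-c3cccc(NC(=O)c4cccc(C(F)(F)F)c4)c3)cc2-c2ccncc2)ccc1Cl`: in a functional assay on OVCAR-3 cells (Homo sapiens) for inhibition, read by sulforhodamine B assay, with a stated time of 48 h (on this read-out lower numbers stand for higher toxicity in this test and higher numbers for lower toxicity in this test), compound 1 gives > 50000 nM, which is a limit of the assay rather than a number.
Compound 2 `COc1cc(-c2nn(-c3cccc(NC(=O)c4ccc(Cl)c(C(F)(F)F)c4)c3)cc2-c2ccncc2)ccc1Cl`: in this assay compound 2 gives > 32500 nM, again only a limit.

Compound 2 therefore stands at a limit, and so does the one other compound shown: the limit of > 32500 nM in this assay, at which 1 of the 2 values shown sits, and the limit of > 50000 nM in this assay, at which 1 of the 2 values shown sits, are the only evidence available. Within the data shown here, both values are limits, so the one measured step, a step that the two limits leave unreadable from compound 1 to compound 2, cannot be read in size or direction; it only shows that adding a chloro to an aromatic carbon left the compound without a measurable number.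

Compound 3 `COc1cc(-c2nn(-c3cccc(NC(=O)c4ccccc4)c3)cc2-c2ccncc2)ccc1Cl` differs from compound 2 by phenyl in place of 4-chloro-3-(trifluoromethyl)phenyl on a carbonyl carbon. Among the measured compounds shown here, no measured step bears directly on this change, and the measured step that exists is unreadable. The expectation is therefore that the step that the limit leaves unreadable from compound 2 to compound 3 stays within the usual scatter, with no direction favoured, and that compound 3 most likely also ends at a limit. Compound 3 is expected to give about 45000 nM in this assay, with a range from 15000 nM to 120000 nM.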

Compound 3, concentration lethal to 50% of the cells: 95800 nM
Estimate against measurement, compound 3: 2.1-fold (0.33 log units) below; the range from low to high includes it.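

Compound 3 gives a number, yet its steps from compound 1 and compound 2 cannot be read, because compound 2 ends at a limit: the limit of > 32500 nM in this assay, at which 1 of the 3 values shown sits. Compound 1 also ends at a limit: the limit of > 50000 nM in this assay, at which 1 of the 3 values shown sits. Left open is whether the trifluoromethyl or the chloro changes the result in this assay at all, and in which direction.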